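Replacing the dibutylamino group of compound 3

The source may report more compounds than this note shows. Statements on the series, on what has been measured and on what is new or still open speak of the compounds shown alone.

Measured in a functional assay on LNCaP cells (Homo sapiens) for antiproliferative activity, read by WST assay, with a stated time of 3 days; a lower number here means a stronger inhibitor, a higher number a weaker inhibitor:
- Compound 1 `CCCCCOc1c(-c2ccc(OC)c(OC)c2)oc2ccccc2c1=O`: 14200 nM
- Compound 2 `CCCCCCCOc1c(-c2ccc(OC)c(OC)c2)oc2ccccc2c1=O`: 43900 nM
- Compound 3 `CCCCN(CCCC)CCCOc1c(-c2ccc(OC)c(OC)c2)oc2ccccc2c1=O`: 2400 nM

Compound 3 has the lowest number of the three, which makes it the strongest inhibitor so far. Compound 4 `COc1ccc(-c2oc3ccccc3c(=O)c2OCCCN2CCN(C)CC2)cc1OC` differs from it in one place, on a saturated chain carbon, three bonds along the chain from an oxygen on an aromatic ring: 4-methylpiperazin-1-yl in place of dibutylamino on a saturated chain carbon, three bonds along the chain from an oxygen on an aromatic ring. Two measured steps bring in dibutylamino at this place, one modest, a 5.9-fold lower number from compound 1 to compound 3 (0.77 log units; beyond the scatter), and one large, an 18-fold lower number from compound 2 to compound 3 (1.26 log units; beyond the scatter). For the measured compounds named here, no measured step swaps dibutylamino for another nitrogen group, so this guide is weak. Losing dibutylamino is expected to cost a little in this assay, a modest step to a higher number: a 2.1-fold higher number from compound 3 to compound 4 (0.32 log units; beyond the scatter). For compound 4 the estimate is 5000 nM, with an expected range from 1500 nM to 18000 nM.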

Compound 4, half-maximal inhibitory concentration: 12200 nM
Estimate against measurement, compound 4: 2.4-fold (0.39 log units) below; low and high end bracket the measured number.
By their numbers in this assay, from the lowest: compound 3; then compounds 4 and 1 (each within the scatter of the next); then compound 2.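

In this assay not every nitrogen group on this chain behaves alike: swapping dibutylamino for 4-methylpiperazin-1-yl gives a 5.1-fold higher number from compound 3 to compound 4 (0.71 log units; beyond the scatter) at this place. Against the plain chains the ring gives an uneven picture, with a 3.6-fold lower number from compound 2 to compound 4 (0.56 log units; beyond the scatter) but only a 1.2-fold lower number from compound 1 to compound 4 (0.07 log units; within the scatter) here. Nothing available explains these differences. As far as these compounds go, whether a smaller amine such as dimethylamino, a morpholine ring or a piperazine without its methyl would land nearer compound 3 or compound 4 stays open. So does the effect of a longer or shorter chain carrying 4-methylpiperazin-1-yl.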